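Sulfamoyl for chloro on the shared core: an anticipated step

The source may report more compounds than this note shows. Statements on the series, on what has been measured and on what is new or still open speak of the compounds shown alone.

Compound 1 `Cc1ccc(-c2nn(-c3ccc(Cl)cc3)cc2-c2cc(-c3ccc(Cl)cc3)[nH]c2-c2ccc(F)cc2)cc1`: 38.3%
Compound 2 `COc1ccc(-c2nn(-c3ccc(Cl)cc3)cc2-c2cc(-c3ccc(Cl)cc3)[nH]c2-c2ccc(F)cc2)cc1`: 53.7%
Compound 3 `COc1ccc(-c2nn(-c3ccc(Cl)cc3)cc2-c2cc(-c3ccc(Cl)cc3)[nH]c2-c2ccc(OC)cc2)cc1`: 10.5%

Of the compounds shown here, three have been measured in a functional assay on the whole organism (strain Wistar albino) for inhibition, with Rattus norvegicus as the target, read by paw edema, with stated times of 1 h and 2 h, at a dose of 0.32 mmol/kg by the intraperitoneal route; a lower number here means less inhibition, a higher number more inhibition at the dose given (going by the name of the read-out). Among them compound 2 gives the highest number, with 53.7%; compound 1 sits closer, the step being a number 15.4 percentage points higher from compound 1 to compound 2 (beyond the scatter), while compound 3 lies far below, the step being a number 43.2 percentage points lower from compound 2 to compound 3 (beyond the scatter). Both measured steps alter a group on an aromatic carbon and both move the read-out beyond the scatter, one modestly and one by a large amount.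

Compound 4 `COc1ccc(-c2nn(-c3ccc(S(N)(=O)=O)cc3)cc2-c2cc(-c3ccc(Cl)cc3)[nH]c2-c2ccc(F)cc2)cc1` is the unmeasured member. It differs from compound 2 in one place: sulfamoyl in place of chloro on an aromatic carbon. Among the compounds with values here, this position, the 4-chlorophenyl to 4-sulfamoylphenyl exchange, is not touched by either measured step, so neither step in this assay bears directly on it; they show only that single changes on aromatic carbons can shift the number substantially in either direction. For that reason the expected step from compound 2 to compound 4 is put near zero, a number 1.3 percentage points higher from compound 2 to compound 4 (within the scatter), with a wide range. Compound 4 is therefore estimated at 55%, expected to fall between 30% and 78% in this assay.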

Compound 4, a percentage reported as inhibition, in the whole organism at one dose (the size of the read-out at that dose, not a potency): 55.7%
The estimate for compound 4 lay 0.7 percentage points below the measured number; the measured number falls inside the stated range.
By their numbers in this assay, from the lowest: compound 3; then compound 1; then compounds 2 and 4 (each within the scatter of the next).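

In this assay, the exchange of 4-chlorophenyl for 4-sulfamoylphenyl comes out as a number 2 percentage points higher from compound 2 to compound 4 (within the scatter), so a change that brings in more heavy atoms, a hydrogen-bond donor and hydrogen-bond acceptors leaves the read-out within the scatter at this position. The earlier compounds shown here could not show this, as neither a number 15.4 percentage points higher from compound 1 to compound 2 (beyond the scatter) nor a number 43.2 percentage points lower from compound 2 to compound 3 (beyond the scatter) touched this aromatic carbon, and both of those steps lay beyond the scatter, whereas this one does not. The data shown offer no explanation for why this exchange leaves the number within the scatter.

The compounds shown leave open whether this position would accept other groups in the same way, such as an amine or a carboxylic acid in place of the chloro, or whether the result is particular to sulfamoyl. They also leave open whether the same exchange would read the same way with the methoxy in place of the fluoro that separates compound 3 from compound 2, given how far that change alone moved the number.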